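A few compounds are considered here, and "the series" means these few. Any claim that something is new, unique, unknown or untested is made for them only; others in the source may bear on it.

Measured compounds: compound 1 `O=C(O)c1nn(Cc2cc(Br)ccc2OCc2ccccc2)cc1F` gives 123 nM in an assay on CHO-K1 cells for displacement of a labelled ligand from prostaglandin E2 receptor EP1 subtype (Homo sapiens); a lower number here means a stronger inhibitor, a higher number a weaker inhibitor; compound 2 `O=C(O)c1nn(Cc2cc(Br)ccc2OCc2ccccc2)cc1C(F)(F)F` gives 2570 nM; compound 3 `Cc1cc(C(=O)O)nn1Cc1cc(Br)ccc1OCc1ccc(F)cc1` gives 7.41 nM.

Compound 1 and compound 2 differ in one place, (trifluoromethyl in place of fluoro on an aromatic carbon), and this change produced a 21-fold higher number from compound 1 to compound 2 (1.32 log units; beyond the scatter). Compound 3 has a core different from that of compound 1; the difference between the two cores is not broken down here. Among the three measured compounds, compound 3 shows the lowest number, with compound 1 nearest and compound 2 furthest.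

Compound 4 `Cc1cc(C(=O)O)nn1Cc1cc(Br)ccc1OCc1ccc(C(F)(F)F)cc1` is not yet measured. It differs from compound 3 by trifluoromethyl in place of fluoro on an aromatic carbon. This is the same kind of change as from compound 1 to compound 2, but not the same: there the group sits on a five-membered aromatic ring with 2 nitrogen, next to the ring atom that bears a carboxy group; here it sits on a six-membered aromatic ring of carbon only, para to a large group. The step from compound 3 to compound 4 is expected to be a 2.7-fold higher number from compound 3 to compound 4 (0.43 log units; beyond the scatter), a weakening resting on a 21-fold higher number from compound 1 to compound 2 (1.32 log units; beyond the scatter) but judged smaller since the place is different. Compound 4 is therefore estimated at 20 nM, between 5 nM and 80 nM.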

Compound 4, half-maximal inhibitory concentration: 35.5 nM
Estimate against measurement, compound 4: 1.8-fold (0.25 log units) below; low and high end bracket the measured number.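

In this assay, trifluoromethyl in place of fluoro on an aromatic carbon gave a 4.8-fold higher number from compound 3 to compound 4 (0.68 log units; beyond the scatter), the same direction as in the earlier pair, but the size of the step did not carry over from one core to the other: the same change on two cores in this assay, a 21-fold higher number (1.32 log units; beyond the scatter) from compound 1 to compound 2 and a 4.8-fold higher number (0.68 log units; beyond the scatter) from compound 3 to compound 4, 4.4-fold (0.64 log units) apart, beyond the scatter of two such steps

The group also sits on a different ring in each pair, so the two steps cannot separate the effect of the core from that of the place. Two pairs also set no rule for the series as a whole.

On these data alone, it remains open what the same change would do in the other place on each core, which would help to separate these two factors. As far as these compounds go, it also remains open whether a chloro, methoxy or nitrile group on the six-membered aromatic ring of carbon only, para to a large group, would give a number nearer that of compound 3 or that of compound 4.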